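A few compounds are considered here, and "the series" means these few. Any claim that something is new, unique, unknown or untested is made for them only; others in the source may bear on it.

In a functional assay on KB cells (Homo sapiens) for cytotoxicity (on this read-out lower numbers stand for an effect already at smaller amounts and higher numbers for an effect only at larger amounts of compound), compound 1 `Cn1ccnc1/C=N/Nc1ccnc2cc(Cl)ccc12` gives 17.1 uM, compound 2 `Clc1ccc2c(N/N=C/c3cnc[nH]3)ccnc2c1` gives 29.1 uM and compound 3 `Clc1ccc2c(N/N=C/c3ncc[nH]3)ccnc2c1` gives 19.5 uM, which places compound 3 within the scatter of both others. Compound 4 `Clc1ccc2c(N/N=C/c3cccs3)ccnc2c1` differs from compound 3 as follows: thiophen-2-yl in place of 1H-imidazol-2-yl on a carbon with a double bond to nitrogen. This puts thiophen-2-yl in place of 1H-imidazol-2-yl on a carbon with a double bond to nitrogen. The measured steps that bear on this change only exchange imidazole groups: a 1.7-fold higher number from compound 1 to compound 2 (0.23 log units; within the scatter), a 1.1-fold higher number from compound 1 to compound 3 (0.06 log units; within the scatter) and a 1.5-fold lower number from compound 2 to compound 3 (0.17 log units; within the scatter). All are small, and none tests thiophen-2-yl itself. In this assay the expected change is therefore none beyond the scatter, with an estimated 1.3-fold lower number from compound 3 to compound 4 (0.11 log units; within the scatter). Compound 4 is expected at 15 uM, within an estimated range of 6 uM to 35 uM.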

Compound 4, concentration for half-maximal effect: 10.4 uM
For compound 4 the middle estimate is 1.4-fold (0.16 log units) above the measured one; the range from low to high includes it.
By their numbers in this assay, from the lowest: compounds 4, 1, 3 and 2 (each within the scatter of the next, the first and the last beyond it).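

In this assay, within the data shown here, thiophen-2-yl on the carbon with a double bond to nitrogen gives a 1.9-fold lower number from compound 3 to compound 4 (0.27 log units; within the scatter) and a 1.6-fold lower number from compound 1 to compound 4 (0.22 log units; within the scatter) but also a 2.8-fold lower number from compound 2 to compound 4 (0.45 log units; beyond the scatter), the first step at this place to pass the scatter. A five-membered aromatic ring with sulfur as its only hetero atom and no hydrogen-bond donor thus keeps the effect on this read-out. Nothing available accounts for this difference. As far as these compounds go, whether a furan-2-yl or phenyl group would match thiophen-2-yl remains open, as does the effect of an amine or carboxylic acid at this place.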